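The source may hold more compounds than are shown below. What is called first, only, known or untested is meant among the compounds shown, and "the series" means these compounds.

Measured compounds:
Compound 1, `O=C(Nc1cccc(-c2ccc(F)cc2)c1)C(Cl)Cl`: 7840 nM
Compound 2, `O=C(Nc1cccc(-c2cccc(NC(=O)C(Cl)Cl)c2)c1)C(Cl)Cl`: 47900 nM
Compound 3, `O=C(Nc1cccc(-c2ccoc2)c1)C(Cl)Cl`: 8480 nM

In a functional assay on A549 cells (Homo sapiens) for cytotoxicity, read by MTT assay, with a stated time of 68 h (a lower number here means a stronger inhibitor, a higher number a weaker inhibitor), compound 1 gives 7840 nM, the lowest number of the three. Compound 3, with 8480 nM, sits so close to it that the two cannot be told apart within the scatter, so neither can be called the more active. Compound 2 is the furthest away, and its number of 47900 nM lies beyond the scatter of compound 1.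

Compound 4, `COC(=O)c1ccc(-c2cccc(NC(=O)C(Cl)Cl)c2)cc1`, has not yet been measured in this assay. It differs from compound 1 in one place: methoxycarbonyl in place of fluoro on an aromatic carbon

Among the compounds with values here, no pair of measured compounds shows this same change, so the size of the step must be judged without a direct precedent. The three measured numbers spread over a modest range, and a step of small size is expected, perhaps a slight rise toward a weaker number, most likely within or just at the edge of the scatter rather than a large change in either direction. The step from compound 1 to compound 4 is therefore estimated as a 1.3-fold higher number from compound 1 to compound 4 (0.11 log units; within the scatter). For compound 4 in this assay the expected value is 10000 nM, with a range from 3000 nM to 35000 nM.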

Compound 4, half-maximal inhibitory concentration: > 50000 nM
Compound 4: only a limit was reported; the forecaster's own chance of this, stated with the estimate: 15%; at least 5.0-fold (0.69 log units) between middle value and limit.
By their numbers in this assay, from the lowest: compounds 1 and 3 (each within the scatter of the next); then compound 2. At a limit, above all of these: compound 4.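

In this assay compound 4 gives only a limit, > 50000 nM, and not a number. Within the data shown here, the change from fluoro to methoxycarbonyl, para to a large group, gives an at least 6.3-fold higher number from compound 1 to compound 4 (0.80 log units; beyond the scatter), which shows that this position does not accept every group alike, something the earlier compounds could not show, as no two of them differ in one place. From the compounds shown here alone, the step is bounded on one side only, and its full size stays unknown: the limit of > 50000 nM in this assay, at which 1 of the 4 values shown sits.

The compounds shown leave open what a carboxylic acid, an amide or a methoxy group would give at this position, and so whether the step belongs to the whole methoxycarbonyl group or only to a part of it. Also open, going by these compounds, is whether an amine or a chlorine here would stay close to compound 1.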